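This account rests on a few compounds, and the source may have more. Where it says the series, first, only, none or still open, it means among the compounds named here.

Measured so far:
- compound 1 `NCCCCCOC[C@H]1O[C@@H](OCCc2c[nH]c3ccccc23)[C@H](OCc2ccccc2)C[C@@H]1OCc1ccccc1`: 3300 nM
- compound 2 `CO[C@@H]1O[C@H](COCCCCCN)[C@@H](OCc2ccccc2)[C@H](OCc2ccccc2)[C@H]1OCc1ccccc1`: 3000 nM

Among the measured compounds shown here, in an assay on isolated protein for binding affinity to somatostatin receptor type 3 (Homo sapiens) (on this read-out lower numbers stand for stronger inhibition and higher numbers for weaker inhibition), compound 1 gives 3300 nM and compound 2 gives 3000 nM; the two numbers lie within the scatter of each other, so compound 1 stands level with the only other measured compound and no order between them can be read. Both sit in the weak range of this assay.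

Compound 3 `NCCCCCOC[C@H]1O[C@@H](OCCc2c[nH]c3ccccc23)[C@H](OCc2c[nH]cn2)C[C@@H]1OCc1ccccc1` is not yet measured. Relative to compound 1 the difference is 1H-imidazol-4-yl in place of phenyl on a saturated chain carbon bound to an oxygen on a saturated carbon. For the measured compounds named here, no measured pair shows the effect of such a change, so the size of the step in this assay is open. Given that compound 1 and compound 2 are already weak and the change is confined to one of the two benzyloxy groups, a step of modest size, in either direction and likely not clearly beyond the scatter, is expected; the step from compound 1 to compound 3 is estimated as a 1.1-fold higher number from compound 1 to compound 3 (0.03 log units; within the scatter). For compound 3 in this assay the expected value is 3500 nM, with a range from 1200 nM to 10000 nM.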

Compound 3, inhibition constant: 6200 nM
Beside the measured number, compound 3's estimate is 1.8-fold (0.25 log units) below it, within the range that was stated.
By their numbers in this assay, from the lowest: compounds 2, 1 and 3 (each within the scatter of the next, the first and the last beyond it).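

In this assay, among the compounds shown here, the exchange of phenyl for 1H-imidazol-4-yl on a saturated chain carbon bound to an oxygen on a saturated carbon gives the first single-place reading (a 1.9-fold higher number from compound 1 to compound 3 (0.27 log units; within the scatter)). At this position, benzyloxy and (1H-imidazol-4-yl)methoxy cannot be told apart on this read-out, although the entering ring carries a hydrogen-bond donor and a hydrogen-bond acceptor and phenyl carries neither. No supporting data bear on this result.

Still open, from the compounds shown here alone, is whether any replacement at this position, such as a carboxylic acid or a primary amine on the chain in place of the ring, moves the number beyond the scatter. Also open, going by these compounds, is whether the remaining benzyloxy group responds in the same way to 1H-imidazol-4-yl.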